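Replacing dimethylamino on the core with a larger amine

The compounds below may be only part of what the source reports. "The series", "measured", "known", "first", "only" and "open" are said of these compounds alone.

Measured compounds:
compound 1 `CC(C(=O)NCc1ccc(C(F)(F)F)nc1N(C)C)c1ccc(NS(C)(=O)=O)c(F)c1`: 19.1 nM
compound 2 `Cc1ccc(CC2CCN(c3nc(C(F)(F)F)ccc3CNC(=O)C(C)c3ccc(NS(C)(=O)=O)c(F)c3)CC2)cc1`: 0.2 nM
compound 3 `CC(C(=O)NCc1ccc(C(F)(F)F)nc1N1CCC(Cc2ccc(F)c(F)c2)CC1)c1ccc(NS(C)(=O)=O)c(F)c1`: 0.2 nM

In a functional assay on CHO-K1 cells for antagonist activity at transient receptor potential cation channel subfamily V member 1 (Homo sapiens), read by FLIPR (a lower number here means a stronger inhibitor, a higher number a weaker inhibitor), compound 1 stands highest of the three, a weaker inhibitor than either of the others; compound 2 gives 0.2 nM and compound 3 gives 0.2 nM, each far below compound 1 and beyond the scatter. Among the measured compounds shown here, the one step between measured compounds, no change at the digits printed from compound 2 to compound 3 (within the scatter), concerns the aryl group on the saturated chain and not the amine on the core, so it does not bear directly on the change at hand.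

Compound 4 `CC(C(=O)NCc1ccc(C(F)(F)F)nc1N1CCN(C2CCCCC2)CC1)c1ccc(NS(C)(=O)=O)c(F)c1` differs from compound 1 by 4-cyclohexylpiperazin-1-yl in place of dimethylamino on an aromatic carbon. For the measured compounds named here, no measured step covers exactly this exchange. What the numbers of compound 1 against compound 2 and compound 3 show is that enlarging the amine on the core, in both cases toward a six-membered saturated ring carrying a further group, goes with a much lower number. Compound 4 carries a saturated ring with a second nitrogen and a cyclohexyl rather than an aryl-bearing chain, so the same size of gain is uncertain, but a sizeable drop is expected: a 13-fold lower number from compound 1 to compound 4 (1.10 log units; beyond the scatter). Compound 4 is therefore estimated at 1.5 nM, within 0.3 nM to 8 nM.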

Compound 4, inhibition constant: 21.6 nM
Compound 4: middle estimate off by 14-fold (1.16 log units), on the low side; the whole stated range lies below it.
By their numbers in this assay, from the lowest: compounds 2 and 3 (each within the scatter of the next); then compounds 1 and 4 (each within the scatter of the next).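

In this assay, 4-cyclohexylpiperazin-1-yl in place of dimethylamino gives a 1.1-fold higher number from compound 1 to compound 4 (0.05 log units; within the scatter), so at this aromatic carbon, next to the ring nitrogen, 12 heavy atoms can enter in place of 3 with no change beyond the scatter. The low numbers of compound 2 (0.2 nM) and compound 3 (0.2 nM) therefore cannot be read as a gain from a larger amine alone: compound 4 goes against that pattern, and its amine differs from theirs both in the second ring nitrogen and in the cyclohexyl that stands where they carry an aryl-bearing chain. Nothing available here gives a reason for this result.

The compounds shown leave open which of those two differences goes with the gap between compound 4 and the pair of compound 2 and compound 3; 4-benzylpiperazin-1-yl, which joins the second ring nitrogen to an aryl-bearing chain, would separate them. Also open, as far as these compounds go, is whether 4-cyclohexylmethylpiperazin-1-yl, with one carbon between the two rings, would stay with compound 4 or move toward compound 2 and compound 3.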